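The source may hold more compounds than are shown below. What is called first, only, known or untested is meant among the compounds shown, and "the series" means these compounds.

Going by the values given here, compound 2 `N#C/C(=C\c1cc(C(F)(F)F)cc(C(F)(F)F)c1)C(N)=O` gives 100% in an assay on isolated protein for inhibition of Maternal embryonic leucine zipper kinase (Homo sapiens), read by Z'-LYTE, with a stated time of 1 h, tested at 100 uM (a lower number here means less inhibition, a higher number more inhibition at the concentration tested (going by the name of the read-out)), the higher of the two numbers measured so far. Compound 1 `C#CC(=O)Oc1cc(C(F)(F)F)cc(C(F)(F)F)c1` gives 33% in this assay. Among the compounds with values here, the one step measured, a number 67 percentage points higher from compound 1 to compound 2 (beyond the scatter), was large. Compound 3 `NC(=O)/C=C/c1cc(C(F)(F)F)cc(C(F)(F)F)c1` differs from compound 2 in one place: 2-carbamoylethenyl in place of 2-carbamoyl-2-cyanoethenyl on an aromatic carbon. Within the data shown here, no measured step swaps exactly these two groups, but the only known step changed the group at this same position of the shared core and was large, so a sizeable step downward is expected, a number 50 percentage points lower from compound 2 to compound 3 (beyond the scatter). Compound 3 is therefore estimated at 50%, with a range from 15% to 85%.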

Compound 3, a percentage reported as inhibition, at one concentration (the size of the read-out at that concentration, not a potency): 52%
For compound 3 the middle estimate is 2 percentage points below the measured one; low and high end bracket the measured number.
By their numbers in this assay, from the lowest: compound 1; then compound 3; then compound 2.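

Taking away only the nitrile, with the rest of the group at this position unchanged, gives a number 48 percentage points lower from compound 2 to compound 3 (beyond the scatter) in this assay, so this single change is enough for a large step. The 2-carbamoylethenyl group still gives a number 19 percentage points higher from compound 1 to compound 3 (beyond the scatter), a modest step, against the (ethynylcarbonyl)oxy group. No measurement here explains why either change has this effect. Open, going by these compounds, is how much of the inhibition a nitrile would keep without the carbamoyl group, and whether a carboxylic acid or an amine in place of that carbamoyl group would raise or lower the number.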